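Swapping the terminal amine on a longer chain

The source may hold more compounds than are shown below. What is called first, only, known or untested is meant among the compounds shown, and "the series" means these compounds.

Compound 1 `CN(C)CCn1c(N)c(-c2nc3ccccc3[nH]2)c2nc(C#N)c(C#N)nc21` and compound 2 `CCN(CC)CCn1c(N)c(-c2nc3ccccc3[nH]2)c2nc(C#N)c(C#N)nc21` share one core and differ only in their terminal amine; the same pair of amines appears on a second core in compound 3 `CN(C)CCCCn1c(N)c(-c2nc3ccccc3o2)c2nc(C#N)c(C#N)nc21` and compound 4 `CCN(CC)CCCCn1c(N)c(-c2nc3ccccc3o2)c2nc(C#N)c(C#N)nc21`. In a functional assay on HeLa cells (Homo sapiens) for antiproliferative activity, read by MTT assay, with a stated time of 48 h (on this read-out higher numbers stand for weaker inhibition and lower numbers for stronger inhibition), compound 1 gives 8880 nM, and compound 2 gives 11600 nM. The change between them is diethylamino in place of dimethylamino on a saturated chain carbon, two bonds along the chain from an aromatic nitrogen, and in this assay it comes to a 1.3-fold higher number from compound 1 to compound 2 (0.12 log units; within the scatter). The difference between the core of compound 1 and the core of compound 3 is not broken down here. In this assay compound 3 gives 1950 nM, the lowest of the three measured numbers, beyond the scatter from both compound 1 and compound 2. Compound 4 carries the change (diethylamino in place of dimethylamino on a saturated chain carbon, four bonds along the chain from an aromatic nitrogen). This is the same kind of change as that from compound 1 to compound 2, but the place differs: there the amine sits two bonds along the chain from an aromatic nitrogen, here four bonds. Resting on the earlier result a 1.3-fold higher number from compound 1 to compound 2 (0.12 log units; within the scatter), compound 4 is expected to shift by a 1.3-fold higher number from compound 3 to compound 4 (0.11 log units; within the scatter) in this assay. Compound 4 is therefore estimated at 2500 nM, within a range from 1200 nM to 5500 nM.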

Compound 4, half-maximal inhibitory concentration: 6420 nM
Compound 4: the middle estimate sits 2.6-fold (0.41 log units) below what was measured; measured number outside the range, above it.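

On the core of compound 3, diethylamino in place of dimethylamino in this assay gives a 3.3-fold higher number from compound 3 to compound 4 (0.52 log units; beyond the scatter), a step beyond the scatter, at the place four bonds along the chain from an aromatic nitrogen. Set beside the same change on the other core, the two steps cannot be told apart: the same change on two cores in this assay, a 1.3-fold higher number (0.12 log units; within the scatter) from compound 1 to compound 2 and a 3.3-fold higher number (0.52 log units; beyond the scatter) from compound 3 to compound 4, 2.5-fold (0.40 log units) apart, within the scatter of two such steps. Among the compounds shown here, this shows no measurable difference in how the change carries from one core to the other, but it does not show that the step is the same on both, since only two pairs are at hand and they differ in chain as well as in core, so any influence of the core cannot be separated from that of the chain.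

The compounds shown leave open whether the swap behaves alike when both chain lengths are carried on a single core. They also leave open what happens with a dipropylamino group as the terminal amine, or with a longer chain.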